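A few compounds are considered here, and "the series" means these few. Any claim that something is new, unique, unknown or untested is made for them only; others in the source may bear on it.

Compound 1 `O=c1[nH]c(=O)n([C@H]2C[C@H](O)[C@@H](CO)O2)cc1-c1cn(-c2ccccc2)nn1` gives 270000 nM in an ADME assay on HEL cells (Homo sapiens) for cytotoxicity, read by cell counting, with a stated time of 3 days; a lower number here means that less compound is tolerated, a higher number that more compound is tolerated. Compound 2 `CC(C)(C)c1ccc(-n2cc(-c3cn([C@H]4C[C@H](O)[C@@H](CO)O4)c(=O)[nH]c3=O)nn2)cc1` gives 230000 nM in this assay. Compound 3 `O=c1[nH]c(=O)n([C@H]2C[C@H](O)[C@@H](CO)O2)cc1-c1cn(-c2ccc(OC(F)(F)F)cc2)nn1` reaches only the limit of > 220000 nM in this assay, at which 1 of the 3 values shown sits, in this assay, so its value > 220000 nM is a limit and not a number.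

Compound 2 holds the lowest of the two numbers shown, and the only readable step to a neighbour, a 1.2-fold lower number from compound 1 to compound 2 (0.07 log units; within the scatter), stays within the scatter. Compound 4 `O=c1[nH]c(=O)n([C@H]2C[C@H](O)[C@@H](CO)O2)cc1-c1cn(-c2ccc(Oc3ccccc3)cc2)nn1` differs from compound 2 by phenoxy in place of tert-butyl on an aromatic carbon. Of the measured steps at this aromatic carbon, a step that the limit leaves unreadable from compound 2 to compound 3 cannot be read, and a 1.2-fold lower number from compound 1 to compound 2 (0.07 log units; within the scatter) shows no change beyond the scatter. Nothing here therefore points to a step beyond the scatter for compound 4, whose expected step is no change at the digits printed from compound 2 to compound 4 (within the scatter). Compound 4 is estimated at 230000 nM, between 100000 nM and 450000 nM.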

Compound 4, minimum cytotoxic concentration: 130000 nM
Beside the measured number, compound 4's estimate is 1.8-fold (0.25 log units) above it; the measured number falls inside the stated range.
By their numbers in this assay, from the lowest: compounds 4, 2 and 1 (each within the scatter of the next, the first and the last beyond it).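

Going by these compounds alone, at this aromatic carbon, phenoxy gives the first step beyond the scatter in this assay, a modest one: a 2.1-fold lower number from compound 1 to compound 4 (0.32 log units; beyond the scatter), while a 1.8-fold lower number from compound 2 to compound 4 (0.25 log units; within the scatter) shows that replacing tert-butyl with phenoxy does not clear the scatter. Against compound 3 there is only a floor, an at least 1.6-fold lower number from compound 3 to compound 4 (0.22 log units; that floor lies within the scatter). Compound 3 holds a limit and not a number, and its steps from compound 1 and compound 2 cannot be read: the limit of > 220000 nM in this assay, at which 1 of the 4 values shown sits.

From the compounds shown here alone, it remains open whether the oxygen or the aromatic ring of phenoxy accounts for the step from hydrogen, and how an amine or a carboxylic acid at this carbon would read.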